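A few compounds are considered here, and "the series" means these few. Any claim that something is new, unique, unknown or untested is made for them only; others in the source may bear on it.

Going by the values given here, in a functional assay on OVCAR-5 cells (Homo sapiens) for inhibition, read by CCK-8 assay, with a stated time of 72 h, tested at 10 uM (a lower number here means less inhibition of growth, a higher number more inhibition of growth at the concentration tested), compound 3 `CN(C)C(=O)c1cc2cnc(Nc3ccc(NC(=O)C4(C(=O)Nc5ccc(Cl)c(C(F)(F)F)c5)CC4)cc3)nc2n1C1CCCC1` gives 48% and stands lowest of the three numbers so far. Compound 1 `CN(C)C(=O)c1cc2cnc(Nc3ccc(NC(=O)C4(C(=O)Nc5cccc(F)c5)CC4)cc3)nc2n1C1CCCC1` gives 85.6% and compound 2 `CN(C)C(=O)c1cc2cnc(Nc3ccc(NC(=O)C4(C(=O)Nc5cccc(Cl)c5)CC4)cc3)nc2n1C1CCCC1` gives 88.1% in the same read-out. The measured change is a number 2.5 percentage points higher from compound 1 to compound 2 (within the scatter) and no order follows from it.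

The change to compound 4 `CN(C)C(=O)c1cc2cnc(Nc3ccc(NC(=O)C4(C(=O)Nc5ccccc5)CC4)cc3)nc2n1C1CCCC1` is phenyl in place of 4-chloro-3-(trifluoromethyl)phenyl on an amide-type nitrogen with the shared core untouched. Among the compounds with values here, two measured steps bear on it. They are a number 37.6 percentage points lower from compound 1 to compound 3 (beyond the scatter) and a number 40.1 percentage points lower from compound 2 to compound 3 (beyond the scatter) and each enters the group that compound 4 leaves. Within the data shown here, both start from a substituted ring, 3-fluorophenyl or 3-chlorophenyl, so neither is a direct reading for plain phenyl, and no such compound has a number yet.

A large upward step is nevertheless expected, close in size to those two but opposite in direction. The estimated move is a number 32 percentage points higher from compound 3 to compound 4 (beyond the scatter) as the working figure. For compound 4 the estimated value is 80% within an expected range of 62% to 93% for now.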

Compound 4, percent growth inhibition at one concentration: 77.1%
Compound 4: middle estimate off by 2.9 percentage points, on the high side; the measured number falls inside the stated range.
By their numbers in this assay, from the lowest: compound 3; then compounds 4, 1 and 2 (each within the scatter of the next, the first and the last beyond it).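

In this assay, plain phenyl on the amide-type nitrogen gives a number 29.1 percentage points higher from compound 3 to compound 4 (beyond the scatter), so this position does not need the 4-chloro-3-(trifluoromethyl)phenyl group to give a high number, and a ring without any substituent is tolerated. The two single halogens do not read alike against hydrogen: the step of a number 11 percentage points lower from compound 2 to compound 4 (beyond the scatter) contrasts with a number 8.5 percentage points lower from compound 1 to compound 4 (within the scatter), so only the removal of chloro separates from the scatter. No measurement shown gives a reason for these steps.

Which part of 4-chloro-3-(trifluoromethyl)phenyl, the chloro or the trifluoromethyl, goes with the low number of compound 3 stays open. Also open, as far as these compounds go, is how a methoxy group or an amine on the phenyl ring, or a cyclohexyl ring in its place, would read in this assay.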